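Switching the nitrile-bearing ring on the amide nitrogen

The compounds below may be only part of what the source reports. "The series", "measured", "known", "first", "only" and "open" are said of these compounds alone.

Measured compounds:
compound 1 `N#C[C@H](COCc1ccccc1)NC(=O)[C@@H](CC(=O)N1CCOCC1)CC1CCCCC1` — 37 nM
compound 2 `CN1CCC(C#N)(NC(=O)[C@@H](CC(=O)N2CCOCC2)CC2CCCCC2)CC1` — 251 nM
compound 3 `N#C[C@@]1(NC(=O)[C@@H](CC(=O)N2CCOCC2)CC2CCc3ccccc3C2)CCN(C2CCCCC2)C1` — 1.9 nM

In an assay on isolated protein for inhibition of cathepsin S (Homo sapiens) (a lower number here means a stronger inhibitor, a higher number a weaker inhibitor), compound 2 gives 251 nM, the highest of the three numbers. Compound 1 sits nearer to it, compound 3 the furthest away, and both gaps lie beyond the scatter of repeated measurement.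

Compound 4 `CC(C)N1CC[C@@](C#N)(NC(=O)[C@@H](CC(=O)N2CCOCC2)CC2CCCCC2)C1` differs from compound 2 in one place: 3-cyano-1-isopropylpyrrolidin-3-yl in place of 4-cyano-1-methylpiperidin-4-yl on an amide-type nitrogen. Among the compounds with values here, no measured pair shows this exact exchange, so the account rests on the three values alone. Compound 3, which also carries a pyrrolidine on that nitrogen, gives 1.9 nM, and this is taken as a pointer towards a lower number. Compound 4 is therefore expected to land at 40 nM, with a plausible range from 8 nM to 200 nM. The step this implies, a 6.3-fold lower number from compound 2 to compound 4 (0.80 log units; beyond the scatter), is estimated to reach beyond the scatter.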

Compound 4, half-maximal inhibitory concentration: 66 nM
Beside the measured number, compound 4's estimate is 1.7-fold (0.22 log units) below it; measured number inside the range.
By their numbers in this assay, from the lowest: compound 3; then compounds 1 and 4 (each within the scatter of the next); then compound 2.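

Within the data shown here, with the rest of the molecule unchanged, 3-cyano-1-isopropylpyrrolidin-3-yl in place of 4-cyano-1-methylpiperidin-4-yl gives a 3.8-fold lower number from compound 2 to compound 4 (0.58 log units; beyond the scatter) in this assay, the first evidence that this group on the amide-type nitrogen alone moves the number. The earlier compounds shown here differ in more than one place and could not show this. No evidence on the cause of the step is available.

The exchange alters ring size and the group on the ring nitrogen together and adds a defined stereocentre, so the step cannot be assigned to any one of these. On these data alone, how 3-cyano-1-methylpyrrolidin-3-yl or 4-cyano-1-isopropylpiperidin-4-yl would compare remains open.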